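The source may hold more compounds than are shown below. What is called first, only, known or untested is meant among the compounds shown, and "the series" means these compounds.

Of the compounds shown here, three have so far been measured in a functional assay on HeLa cells (Homo sapiens) for inhibition, read by CCK-8 assay, with a stated time of 48 h; a higher number here means a weaker inhibitor, a lower number a stronger inhibitor. Compound 2 `COc1cc(-c2ccnc3cc(-c4ccc5cc[nH]c5c4)nn23)cc(OC)c1OC` gives 125 nM in this assay, the lowest of the two numbers that were reported. Compound 1 `Cn1ccc2cc(-c3cc4nccc(-c5ccc(F)cc5)n4n3)ccc21` gives 5210 nM in this assay, a much higher number, and the gap between the two lies well beyond the usual scatter of repeated measurements. Compound 3 `COc1ccc(-c2cc3nccc(-c4cc(OC)c(OC)c(OC)c4)n3n2)cc1[N+](=O)[O-]` has no number at all in this assay: what was recorded for it is a limit, > 10000 nM, at the edge of what the measurement can report (the limit of > 10000 nM in this assay, at which 1 of the 3 values shown sits).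

Compound 4 `COc1cc(-c2ccnc3cc(-c4ccc5ccn(C)c5c4)nn23)cc(OC)c1OC` has not yet been measured. It differs from compound 2 in a single place (methyl in place of hydrogen on an aromatic nitrogen), so that the 1H-indol-6-yl group of compound 2 becomes a 1-methyl-1H-indol-6-yl group. For the measured compounds named here, no pair of measured compounds differs in just this way, so no measured step shows what this change does. Compound 1 also carries a methyl on an aromatic nitrogen, yet it differs from compound 2 in other places as well, so its high number cannot be traced to the methyl alone.

The change is expected to raise the number in this assay by a step of a 3.6-fold higher number from compound 2 to compound 4 (0.56 log units; beyond the scatter), beyond the scatter but far from the limit. Compound 4 is estimated at 450 nM, with a likely range from 120 nM to 2000 nM.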

Compound 4, half-maximal inhibitory concentration: 187 nM
For compound 4 the middle estimate is 2.4-fold (0.38 log units) above the measured one, within the range that was stated.
By their numbers in this assay, from the lowest: compounds 2 and 4 (each within the scatter of the next); then compound 1. At a limit, above all of these: compound 3.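

In this assay, putting a methyl in place of the hydrogen on the aromatic nitrogen, which turns the 1H-indol-6-yl group into a 1-methyl-1H-indol-6-yl group, gives a 1.5-fold higher number from compound 2 to compound 4 (0.17 log units; within the scatter), so the two compounds cannot be told apart in this assay. For the compounds shown here, this is the first direct reading of this change at this position, and it shows that, on this core, the hydrogen on that nitrogen is not needed for a number of this size. The compounds shown offer no measurement that explains why the methyl makes no clear difference here.

What the compounds shown leave open is how much room this nitrogen allows: a longer chain such as ethyl or propyl, or a chain ending in an amine or a carboxylic acid, could keep the number in this range or could raise it well beyond the scatter. Going by these compounds alone, they also leave open whether the same swap of hydrogen for methyl would read the same way on a core carrying different groups, as no measured pair tests that.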